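Swapping the Aryl Group on the Sulfonyl: Compound 3 to 4

The source may hold more compounds than are shown below. What is called first, only, known or untested is meant among the compounds shown, and "the series" means these compounds.

Measured so far in a functional assay on DLD-1 cells (Homo sapiens) for antiproliferative activity, read by CellTiter-Glo, with a stated time of 72 h; a lower number here means a stronger inhibitor, a higher number a weaker inhibitor:
Compound 1 `Cc1cc(C)c(S(=O)(=O)N2CCC(N3CCC(C)CC3)CC2)c(C)c1` gives 0.03 nM.
Compound 2 `Cc1ccc(-c2ccccc2S(=O)(=O)N2CCC(N3CCC(C)CC3)CC2)cc1` gives 366 nM.
Compound 3 `CC1CCN(C2CCN(S(=O)(=O)c3cccnc3Cl)CC2)CC1` gives only a limit of the assay, > 5000 nM.

All three share one core and differ only in the group on the sulfonyl sulfur. Compound 3 stands at the weak end of what has been seen, where this assay reports no number; one of the three values sits there (the limit of > 5000 nM in this assay, at which 1 of the 3 values shown sits). Compound 4 `CC1CCN(C2CCN(S(=O)(=O)c3cccc(N)c3)CC2)CC1` carries 3-aminophenyl in place of 2-chloropyridin-3-yl on a sulfonyl sulfur. For the measured compounds named here, no measured pair differs in exactly this way, so the size of the effect is open. Compounds 1 and 2 show that other aryl groups on this sulfonyl can give strong inhibition. The step is therefore expected to move toward a stronger inhibitor by an at least 1.6-fold lower number from compound 3 to compound 4 (0.22 log units; that floor lies within the scatter), though a limit may again be reported. Compound 4 is estimated at 3000 nM, within 300 nM to 20000 nM.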

Compound 4, half-maximal inhibitory concentration: 3400 nM
Compound 4: the middle estimate sits 1.1-fold (0.05 log units) below what was measured; measured number inside the range.
By their numbers in this assay, from the lowest: compound 1; then compound 2; then compound 4. At a limit, above all of these: compound 3.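

Putting 3-aminophenyl in place of 2-chloropyridin-3-yl on the sulfonyl sulfur gives a value that this assay can report as a number, with an at least 1.4-fold lower number from compound 3 to compound 4 (0.16 log units; that floor lies within the scatter). Compound 3 itself remains a limit, not a number: the limit of > 5000 nM in this assay, at which 1 of the 4 values shown sits. Compound 4, at 3400 nM, stays far from compound 1, at 0.03 nM.

The change swaps the ring nitrogen, the chlorine and the amine all at once, so the compounds shown leave open which of these matters. A plain phenyl group on this sulfur would help to separate them.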